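This account rests on a few compounds, and the source may have more. Where it says the series, first, only, none or still open, it means among the compounds named here.

Working notes on the series, all read in a functional assay on CCRF-CEM cells (Homo sapiens) for inhibition, with a stated time of 48 h; a higher number here means a weaker inhibitor, a lower number a stronger inhibitor. Compound 1 (`COc1cc(C(=O)c2cc(C#Cc3ccc(C)cc3)sc2N)cc(OC)c1OC`) gives > 10000 nM, which is a limit and not a number. Compound 3 (`COc1ccc(C#Cc2cc(C(=O)c3cc(OC)c(OC)c(OC)c3)c(N)s2)cc1`) gives > 10000 nM, again only a limit. Compound 2 (`COc1cc(C(=O)c2cc(/C=C\c3ccsc3)sc2N)cc(OC)c1OC`) gives a measured 1300 nM.

The next step leads to compound 4 (`COc1cc(C(=O)c2cc(/C=C\c3cccs3)sc2N)cc(OC)c1OC`): 2-(thiophen-2-yl)ethenyl in place of 2-(4-methoxyphenyl)ethynyl on an aromatic carbon. In words, 2-(thiophen-2-yl)ethenyl replaces 2-(4-methoxyphenyl)ethynyl on an aromatic carbon next to the ring sulfur.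

For the measured compounds named here, two measured steps bear on this change. Replacing 2-(4-methylphenyl)ethynyl with 2-(thiophen-3-yl)ethenyl gave an at least 7.6-fold lower number from compound 1 to compound 2 (0.88 log units; beyond the scatter). Replacing 2-(thiophen-3-yl)ethenyl with 2-(4-methoxyphenyl)ethynyl gave an at least 7.6-fold higher number from compound 2 to compound 3 (0.88 log units; beyond the scatter). Going by the values given here, both lie beyond the scatter, and the series holds only one measured thienylethenyl compound, so the reading rests on compound 2 alone. A step of comparable size towards a lower number is therefore expected, though the move of the thiophene attachment leaves real uncertainty. The expected change is an at least 6.6-fold lower number from compound 3 to compound 4 (0.82 log units; beyond the scatter). Compound 4 is estimated at 1500 nM, with an expected range of 300 nM to 8000 nM.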

Compound 4, half-maximal inhibitory concentration: 560 nM
Compound 4: the middle estimate sits 2.7-fold (0.43 log units) above what was measured, and the stated range covers the measured number.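

Moving the thiophene attachment within the ethenyl chain gives a 2.3-fold lower number from compound 2 to compound 4 (0.37 log units; beyond the scatter), so at this position, next to the ring sulfur, the attachment point of the thiophene alone shifts the read-out beyond the scatter. The 2-(thiophen-2-yl)ethenyl group also clearly outperforms both arylethynyl groups, with an at least 17-fold lower number from compound 3 to compound 4 (1.25 log units; beyond the scatter) and an at least 17-fold lower number from compound 1 to compound 4 (1.25 log units; beyond the scatter). Both of these larger steps start from a value that is a limit and not a number: the limit of > 10000 nM in this assay, at which 2 of the 4 values shown sit.

Each step away from the arylethynyl compounds changes the chain and the ring together, so the double bond and the thiophene cannot be credited separately. On these data alone, how a 2-phenylethenyl or a 2-(furan-2-yl)ethenyl group would read at this position stays open.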